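The source may hold more compounds than are shown below. What is called first, only, known or untested is meant among the compounds shown, and "the series" means these compounds.

Compound 1, with the structure `C#CCN(C)C(=O)c1nc2ccccc2n1Cc1ccc(Cl)cc1`, carries a chlorine on its benzyl group and an unsubstituted shared core. In an assay on membranes from HEK293 cells for displacement of a labelled ligand from Translocator protein (Homo sapiens), read by scintillation counting, with a stated time of 90 min (on this read-out lower numbers stand for stronger inhibition and higher numbers for weaker inhibition), compound 1 reaches only the assay limit, reported as > 10000 nM, which is a limit and not a number; this is the case noted in the limit of > 10000 nM in this assay, at which 1 of the 2 values shown sits.

Compound 2, with the structure `C#CCN(C)C(=O)c1cc2cc(NC(C)=O)ccc2n1Cc1ccc(OC)cc1`, has a methoxy on the benzyl group and an acetamido group on its core. In this assay compound 2 gives 2070 nM, the only number shown so far.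

Compound 3, with the structure `C#CCN(C)C(=O)c1cc2cc(NS(C)(=O)=O)ccc2n1Cc1ccc(OC)cc1`, is not yet measured. It differs from compound 2 in one place: methylsulfonyl in place of acetyl on a nitrogen on an aromatic ring. For the measured compounds named here, no measured pair shows this exact change, so the size of the step is open. The acetamido and methanesulfonamido groups are both neutral and both sit on the same nitrogen, so the expected step from compound 2 to compound 3 is small, a 1.4-fold higher number from compound 2 to compound 3 (0.16 log units; within the scatter), within the usual scatter and leaning toward weaker binding. In this assay compound 3 is therefore expected to give 3000 nM, with a plausible range from 700 nM to 12000 nM.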

Compound 3, inhibition constant: 1500 nM
The estimate for compound 3 lay 2.0-fold (0.30 log units) above the measured number; measured number inside the range.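

Compound 2 and compound 3 form the first pair shown that differs in one place, and so give the first direct reading at this position, the nitrogen on an aromatic ring. In this assay, exchanging acetyl for methylsulfonyl, that is acetamido for methanesulfonamido, gives a 1.4-fold lower number from compound 2 to compound 3 (0.14 log units; within the scatter), so this read-out does not tell the two groups apart. Methylsulfonyl brings more heavy atoms, a sulfur and more hydrogen-bond acceptors than acetyl, and this place accepts that exchange with no step beyond the scatter, though nothing shown here gives a reason for this result.

The compounds shown leave open whether a free amine or a carboxylic acid at this place, or a longer chain in place of the methyl on the sulfonyl, would carry the number beyond the scatter. They also leave open what the methoxy on the benzyl group contributes, as compound 2 and compound 3 both carry it and no step shown replaces it.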